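Iodo in place of chloro, carried to compound 3

This account rests on a few compounds, and the source may have more. Where it says the series, first, only, none or still open, it means among the compounds named here.

Measured compounds and values:
compound 1 `NC(=O)c1cc(CCl)[nH]n1`: > 100 ug/mL
compound 2 `NC(=O)c1cc(CI)[nH]n1`: > 100 ug/mL
compound 3 `CCOC(=O)c1cc(CCl)nn1[C@@H]1O[C@H](COC(C)=O)[C@@H](OC(C)=O)[C@H]1OC(C)=O`: 32 ug/mL

Going by the values given here, in a functional assay on HeLa cells (Homo sapiens) (on this read-out higher numbers stand for an effect only at larger amounts of compound and lower numbers for an effect already at smaller amounts), compound 3 gives 32 ug/mL, the only number among the three. For compound 1 the result is a limit, > 100 ug/mL. For compound 2 the result is likewise a limit, > 100 ug/mL. Compound 2 differs from compound 1 by iodo in place of chloro on a saturated chain carbon bound to an aromatic carbon, and the step that the two limits leave unreadable from compound 1 to compound 2 cannot be sized because of the limit of > 100 ug/mL in this assay, at which 2 of the 3 values shown sit. Compound 4 `CCOC(=O)c1cc(CI)nn1[C@@H]1O[C@H](COC(C)=O)[C@@H](OC(C)=O)[C@H]1OC(C)=O` differs from compound 3 by iodo in place of chloro on a saturated chain carbon bound to an aromatic carbon, the same change at the same place; the difference between the two cores is not broken down here. With the measured instance unreadable, the expectation for compound 4 rests on compound 3 alone, whose value 32 ug/mL is taken over with an expected step of no change at the digits printed from compound 3 to compound 4 (within the scatter). Compound 4 is therefore estimated at 32 ug/mL, between 10 ug/mL and 100 ug/mL.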

Compound 4, concentration for half-maximal effect: 5.5 ug/mL
The estimate for compound 4 lay 5.8-fold (0.76 log units) above the measured number, and the stated range ends above it.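

In this assay, iodo in place of chloro on a saturated chain carbon bound to an aromatic carbon gives a 5.8-fold lower number from compound 3 to compound 4 (0.76 log units; beyond the scatter), so on this core the change has a real effect. The same change on the core of compound 1 cannot be read, because the values of both compound 1 and compound 2 are limits: the limit of > 100 ug/mL in this assay, at which 2 of the 4 values shown sit. Going by these compounds alone, the series therefore holds only one readable instance of this change, and it does not show whether the step carries from one core to the other.

The compounds shown leave open how a bromomethyl group would read at the same place. They also leave open whether the step would hold with a carboxylic acid in place of the ethyl ester.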